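A few compounds are considered here, and "the series" means these few. Any claim that something is new, unique, unknown or untested is made for them only; others in the source may bear on it.

Compound 1 `Cc1noc(C)c1S(=O)(=O)N1CCC(N2CCC(C)CC2)CC1` gives > 5000 nM in a functional assay on DLD-1 cells (Homo sapiens) for antiproliferative activity, read by CellTiter-Glo, with a stated time of 72 h; on this read-out lower numbers stand for stronger inhibition and higher numbers for weaker inhibition; this value is a limit of the assay, not a number.
Compound 2 `CC1CCN(C2CCN(S(=O)(=O)c3ccc(F)cc3F)CC2)CC1` gives 102 nM.
Compound 3 `CC1CCN(C2CCN(S(=O)(=O)c3cnc(Cl)s3)CC2)CC1` gives 1800 nM.

Of the two actual numbers, compound 3 holds the higher one; its nearest neighbour is reached by the step of an 18-fold higher number from compound 2 to compound 3 (1.25 log units; beyond the scatter), which lies well beyond the scatter. Compound 4 `Cc1ccc(S(=O)(=O)N2CCC(N3CCC(C)CC3)CC2)cc1C` has not yet been measured. It differs from compound 3 in one place: 3,4-dimethylphenyl in place of 2-chloro-1,3-thiazol-5-yl on a sulfonyl sulfur. The measured steps that bear on this change are those in which the group on the sulfonyl sulfur was swapped between a ring with hetero atoms and a six-membered aromatic ring of carbon only. The step of an at least 49-fold lower number from compound 1 to compound 2 (1.69 log units; beyond the scatter) was large, and so was the reverse kind of swap, an 18-fold higher number from compound 2 to compound 3 (1.25 log units; beyond the scatter); the smaller step of an at least 2.7-fold lower number from compound 1 to compound 3 (0.44 log units; beyond the scatter) ran between two rings that both carry hetero atoms. Since compound 4 again places a six-membered aromatic ring of carbon only on the sulfonyl sulfur, a large lowering of the number is expected, estimated as a 12-fold lower number from compound 3 to compound 4 (1.08 log units; beyond the scatter). Compound 4 is therefore expected to give about 150 nM in this assay, with a likely range from 40 nM to 600 nM.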

Compound 4, half-maximal inhibitory concentration: 24 nM
Compound 4: the middle estimate sits 6.3-fold (0.80 log units) above what was measured, and the stated range ends above it.
By their numbers in this assay, from the lowest: compound 4; then compound 2; then compound 3. At a limit, above all of these: compound 1.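

In this assay, the 3,4-dimethylphenyl group gives compound 4 the lowest number of the set, and the change from 2-chloro-1,3-thiazol-5-yl on the sulfonyl sulfur produces the widest spread yet seen between two actual numbers, a 75-fold lower number from compound 3 to compound 4 (1.88 log units; beyond the scatter). Among these compounds, the earlier compounds held only one six-membered aromatic ring of carbon only at this place, whereas a second such ring now shows that the choice within this ring type also counts, with a modest step of a 4.3-fold lower number from compound 2 to compound 4 (0.63 log units; beyond the scatter). The remaining step, an at least 200-fold lower number from compound 1 to compound 4 (2.31 log units; beyond the scatter), is a bound and not a measured gap, because its starting value is a limit: the limit of > 5000 nM in this assay, at which 1 of the 4 values shown sits.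

The compounds shown leave open whether either methyl group of the 3,4-dimethylphenyl ring would suffice alone, or whether both are needed for the number seen with compound 4. They also leave open how the number would move if a methoxy group, an amine or a carboxylic acid stood on that ring in place of a methyl group.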